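From dimethylamino to cyclopropylamino on a carbonyl carbon

The source may hold more compounds than are shown below. What is called first, only, known or untested is meant among the compounds shown, and "the series" means these compounds.

Compound 1 `CN1CCN(C(=O)/C=C/c2ccncc2-c2ccc3ccccc3c2)CC1`: > 10000 nM (a limit)
Compound 2 `CN(C)C(=O)/C=C/c1ccncc1-c1ccc2ccccc2c1`: 8190 nM

Within the data shown here, in a functional assay on MCF7 cells (Homo sapiens) for inhibition, read by sulforhodamine B assay, with a stated time of 72 h (a lower number here means a stronger inhibitor of growth, a higher number a weaker inhibitor of growth), compound 2 gives 8190 nM, the only actual number so far. Compound 1 is reported only as a limit, > 10000 nM; this is the limit of > 10000 nM in this assay, at which 1 of the 2 values shown sits.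

Compound 3 `O=C(/C=C/c1ccncc1-c1ccc2ccccc2c1)NC1CC1` carries cyclopropylamino in place of dimethylamino on a carbonyl carbon. Among the measured compounds shown here, one measured step bears on this change, since it also falls on a carbonyl carbon: an at least 1.2-fold lower number from compound 1 to compound 2 (0.08 log units; that floor lies within the scatter). That step is a floor within the scatter, so it gives no firm size or direction for the next change. In this assay, no shift beyond the scatter is therefore expected, and the expected step is a 1.0-fold lower number from compound 2 to compound 3 (0.01 log units; within the scatter). For compound 3 the estimated value is 8000 nM, with an expected range of 3000 nM to 16000 nM.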

Compound 3, concentration for 50% growth inhibition: 6840 nM
Beside the measured number, compound 3's estimate is 1.2-fold (0.07 log units) above it; measured number inside the range.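

In this assay, among these compounds, replacing dimethylamino with cyclopropylamino on the carbonyl carbon brings in a three-membered ring and the amide hydrogen, yet gives a 1.2-fold lower number from compound 2 to compound 3 (0.08 log units; within the scatter), the first step here between two actual numbers, and it shows no shift beyond the scatter. The other comparison, an at least 1.4-fold lower number from compound 1 to compound 3 (0.16 log units; that floor lies within the scatter), is only a floor. Compound 1 stands only as a limit, so its true distance from the others stays unknown: the limit of > 10000 nM in this assay, at which 1 of the 3 values shown sits.

Going by these compounds, whether a morpholine, a primary amide or a carboxylic acid on this carbonyl carbon would move the number beyond the scatter remains open. All three compounds share one core, so what a change on the core itself would do is open as well.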